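From pyridin-2-yl to 3-fluorophenyl on a shared core

The source may hold more compounds than are shown below. What is called first, only, known or untested is meant among the compounds shown, and "the series" means these compounds.

Three measured compounds share one core and differ only in the group on an amide-type nitrogen in a ring: compound 1 `COc1ccc(F)cc1N1C(=O)CSC1c1cccc(C(=O)NCCCCc2ccccc2)c1` with 5-fluoro-2-methoxyphenyl, compound 2 `Cc1cccc(N2C(=O)CSC2c2cccc(C(=O)NCCCCc3ccccc3)c2)c1` with 3-methylphenyl and compound 3 `O=C(NCCCCc1ccccc1)c1cccc(C2SCC(=O)N2c2ccccn2)c1` with pyridin-2-yl. In a physicochemical assay for solubility, read by turbidimetry, measured as kinetic solubility, at pH 6.8 (on this read-out higher numbers stand for higher solubility and lower numbers for lower solubility), compound 1 gives 10000 nM and compound 2 gives 10000 nM in the same test, while compound 3 gives 20000 nM there. Compound 3 therefore stands within the usual scatter of both others, and the three numbers cannot be ranked.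

The next compound, compound 4 `O=C(NCCCCc1ccccc1)c1cccc(C2SCC(=O)N2c2cccc(F)c2)c1`, carries 3-fluorophenyl in place of pyridin-2-yl, and the counted difference is this: 3-fluorophenyl in place of pyridin-2-yl on an amide-type nitrogen in a ring (nothing else changes). Among the measured compounds shown here, three measured steps bear on it, all made at that same place. Exchanging one carbon-only aromatic group for another gives no change at the digits printed from compound 1 to compound 2 (within the scatter) in the data, and bringing in pyridin-2-yl gives a 2.0-fold higher number from compound 1 to compound 3 (0.30 log units; within the scatter) in one case and a 2.0-fold higher number from compound 2 to compound 3 (0.30 log units; within the scatter) in the other. None of these goes beyond the scatter, though three compounds are a small basis.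

In this assay the expected result is a 2.0-fold lower number from compound 3 to compound 4 (0.30 log units; within the scatter) and no step beyond the scatter. For compound 4 the estimated value is 10000 nM with an expected range from 5000 nM to 20000 nM in this test.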

Compound 4, solubility: 10000 nM
Compound 4: the middle estimate sits on the measured number at the digits printed, and the stated range covers the measured number.
By their numbers in this assay, from the lowest: compounds 1, 2, 4 and 3 (each within the scatter of the next).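

In this assay, pyridin-2-yl, a ring with 1 hetero atom and 1 hydrogen-bond acceptor, gives way to 3-fluorophenyl, a ring of carbon only with 0 hydrogen-bond acceptors, and the result is a 2.0-fold lower number from compound 3 to compound 4 (0.30 log units; within the scatter) so even this exchange on the amide-type nitrogen stays within the usual scatter. The comparisons with the two other carbon-only aromatic groups read the same way: fluoro in place of methyl on an aromatic carbon gives no change at the digits printed from compound 2 to compound 4 (within the scatter) and hydrogen in place of methoxy on an aromatic carbon gives no change at the digits printed from compound 1 to compound 4 (within the scatter) while the fourth group therefore adds one more aromatic ring at this position with no step beyond the scatter. Nothing measured alongside these numbers offers an explanation for this flat picture.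

Still open, going by these compounds, is whether a group at this position that is not a simple aromatic ring, such as a piperidine ring or a longer alkyl chain, or an aromatic ring carrying an amine or a carboxylic acid, would give a step beyond the scatter. Also open, on these data alone, is whether a change elsewhere on the shared core would do so.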